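This account rests on a few compounds, and the source may have more. Where it says the series, first, only, none or still open, it means among the compounds named here.

Measured so far:
Compound 1, `COc1nc2ccc(CSc3ccc(Cl)c(Cl)c3)cc2nc1OC`: in an ADME assay on BHK-21 cells (Mesocricetus auratus) for cytotoxicity, read by MTT assay, with a stated time of 96 h (a lower number here means that less compound is tolerated, a higher number that more compound is tolerated), compound 1 gives 80000 nM.
Compound 2, `COc1nc2ccc(CSc3ccccn3)cc2nc1OC`: in this assay compound 2 gives > 100000 nM, which is a limit of the assay and not a number.

Compound 2 thus stands at the upper edge of what this assay can report; of the two measured values it is the one at the limit, as the limit of > 100000 nM in this assay, at which 1 of the 2 values shown sits, shows. Within the data shown here, the single measured step, an at least 1.2-fold higher number from compound 1 to compound 2 (0.09 log units; that floor lies within the scatter), reaches only that limit, so its true size is unknown.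

Compound 3, `CCOC(=O)c1ccc(SCc2ccc3nc(OC)c(OC)nc3c2)nc1`, differs from compound 2 in one place: ethoxycarbonyl in place of hydrogen on an aromatic carbon. Among the measured compounds shown here, no measured step adds a group to that ring; the only step touching it is the exchange of the whole ring described by an at least 1.2-fold higher number from compound 1 to compound 2 (0.09 log units; that floor lies within the scatter), and that gave merely a floor within the scatter. For the measured compounds named here, the ethoxycarbonyl group itself has no measured counterpart here. Compound 3 is therefore expected to show a number no higher from compound 2 to compound 3 (the limit leaves the size open), a step not expected to go beyond the scatter. In this assay compound 3 is expected at 100000 nM, ranging from 40000 nM to 250000 nM, and may again be reported only as a limit.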

Compound 3, half-maximal cytotoxic concentration: > 100000 nM
Compound 3 gave a limit, no number (the forecaster's own chance of this, stated with the estimate: 60%); the middle value lies on the limit itself.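

Compound 2 and compound 3 both stop at the same limit in this assay, a limit and not a number, so no step between them can be read: the limit of > 100000 nM in this assay, at which 2 of the 3 values shown sit.

The compounds shown leave open how much of compound 2 or compound 3 the cells actually tolerate, and whether ethoxycarbonyl in place of hydrogen changes that at all.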